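The source may report more compounds than this note shows. Statements on the series, on what has been measured and on what is new or still open speak of the compounds shown alone.

Compound 3, with structure `COC(=O)CNc1c(C(=O)NCc2ccc(F)cc2)nc(Br)c2cccnc12`, is one of three compounds tested in a functional assay on MDA-MB-435 cells (Homo sapiens) for cytotoxicity, read by MTT assay, with a stated time of 72 h; a lower number here means a stronger inhibitor, a higher number a weaker inhibitor; compound 3 gives 10000 nM, the highest of the two numbers measured, and its nearest neighbour is compound 2, with structure `Nc1ccc(Nc2c(C(=O)NCc3ccc(F)cc3)nc(Br)c3cccnc23)cc1`, which gives 7000 nM, a gap of a 1.4-fold higher number from compound 2 to compound 3 (0.15 log units; within the scatter). Compound 1, with structure `CS(=O)(=O)Oc1c(C(=O)NCc2ccc(F)cc2)nc(Br)c2cccnc12`, gives only a limit in this assay, > 20000 nM; the step of an at least 2.0-fold lower number from compound 1 to compound 3 (0.30 log units; that floor lies within the scatter) is therefore a floor. Compound 4, with structure `O=C(NCc1ccc(F)cc1)c1nc(Br)c2cccnc2c1N1CCNCC1`, is not yet measured, and differs from compound 3 in one place: piperazin-1-yl in place of ((methoxycarbonyl)methyl)amino on an aromatic carbon. Among the measured compounds shown here, the steps that bear on this change are those that vary the group on that same aromatic carbon, and within the measured compounds they were small: the step from compound 2 to compound 3 lies within the scatter, and the step from compound 1 to compound 3 reaches only its floor. No step beyond the scatter is therefore expected for compound 4 in this assay. Compound 4 is expected to give about 8000 nM, between 2500 nM and 25000 nM, an expected step of a 1.3-fold lower number from compound 3 to compound 4 (0.10 log units; within the scatter).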

Compound 4, half-maximal inhibitory concentration: 8000 nM
Beside the measured number, compound 4's estimate shows no gap at the digits printed; the measured number falls inside the stated range.
By their numbers in this assay, from the lowest: compounds 2, 4 and 3 (each within the scatter of the next). At a limit, above all of these: compound 1.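

In this assay, piperazin-1-yl, a six-membered non-aromatic ring, sits on this aromatic carbon with no step beyond the scatter against either earlier nitrogen-linked group, a 1.3-fold lower number from compound 3 to compound 4 (0.10 log units; within the scatter) and a 1.1-fold higher number from compound 2 to compound 4 (0.06 log units; within the scatter), so the hydrogen on the attached nitrogen of compounds 2 and 3, absent in compound 4, does not show up in this read-out. Compound 4 also joins compound 2 in clearing the scatter against the (methylsulfonyl)oxy group, with an at least 2.5-fold lower number from compound 1 to compound 4 (0.39 log units; beyond the scatter). The value of compound 1 is a limit, so this step is only a floor: the limit of > 20000 nM in this assay, at which 1 of the 4 values shown sits.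

The compounds shown leave open whether a carboxylic acid in place of the methyl ester, or an acetyl group on the free piperazine nitrogen, would separate from these three. They also leave open what replacing the bromo group with a simple amine would do.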